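Adding trifluoromethyl to a weak growth inhibitor

The source may hold more compounds than are shown below. What is called first, only, known or untested is meant among the compounds shown, and "the series" means these compounds.

- compound 1 `Cc1ccc2[nH]c(-c3ccc(-c4ccc(-c5ccc(N(C)C)cc5)cc4)cc3)nc2c1` gives 6240 nM
- compound 2 `FC(F)(F)c1ccc(-c2ccc(-c3ccc(-c4nc5ccccc5[nH]4)cc3)cc2)cc1` gives 47200 nM
- compound 3 `Cc1ccc2[nH]c(-c3ccc(-c4ccc(-c5ccccc5)cc4)cc3)nc2c1` gives 32100 nM

In a functional assay on KB cells (Homo sapiens) for inhibition, read by sulforhodamine B assay (on this read-out higher numbers stand for weaker inhibition of growth and lower numbers for stronger inhibition of growth), compound 3 lies within the scatter of compound 2 and well above compound 1. Going by the values given here, the one measured step that bears on this place is a 5.1-fold higher number from compound 1 to compound 3 (0.71 log units; beyond the scatter), which is modest but beyond the scatter. Compound 4 `Cc1ccc2[nH]c(-c3ccc(-c4ccc(-c5ccc(C(F)(F)F)cc5)cc4)cc3)nc2c1` has trifluoromethyl in place of hydrogen on an aromatic carbon, para to a large group (trifluoromethyl in place of hydrogen on an aromatic carbon). Among the compounds with values here, no measured step makes this exact change. The closest guide is compound 2, which also carries trifluoromethyl and gives 47200 nM, so no step beyond the scatter is expected in this assay. The expected change is a 1.1-fold higher number from compound 3 to compound 4 (0.05 log units; within the scatter). The estimate for compound 4 is 36000 nM, with a range of 16000 nM to 75000 nM.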

Compound 4, concentration for 50% growth inhibition: 41200 nM
Beside the measured number, compound 4's estimate is 1.1-fold (0.06 log units) below it; measured number inside the range.
By their numbers in this assay, from the lowest: compound 1; then compounds 3, 4 and 2 (each within the scatter of the next).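

In this assay the change from phenyl to 4-(trifluoromethyl)phenyl gives a 1.3-fold higher number from compound 3 to compound 4 (0.11 log units; within the scatter) and does not separate the two compounds. Trifluoromethyl therefore does not match dimethylamino at this place, with a 6.6-fold higher number from compound 1 to compound 4 (0.82 log units; beyond the scatter) as the step between these two groups. Methyl in place of hydrogen on the core, read as a 1.1-fold lower number from compound 2 to compound 4 (0.06 log units; within the scatter) here, also makes no difference beyond the scatter. Nothing measured here explains these numbers. Still open, from the compounds shown here alone, is whether a plain amino group or a carboxylic acid at this place would act as dimethylamino does.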